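A few compounds are considered here, and "the series" means these few. Any claim that something is new, unique, unknown or untested is made for them only; others in the source may bear on it.

The measured compounds in a functional assay on K562 cells (Homo sapiens) for antiproliferative activity, read by MTT assay, with a stated time of 48 h; on this read-out lower numbers stand for stronger inhibition and higher numbers for weaker inhibition:
Compound 1, `CN(C)C(=O)N(Cc1cccc([N+](=O)[O-])c1)Cc1ccco1`: compound 1 gives 35400 nM.
Compound 2, `CCOC(=O)N1CCC(N(Cc2cc(Cl)ccc2O)C(=O)N(C)C)CC1`: compound 2 gives 38400 nM.
Compound 3, `CN(C)C(=O)N(Cc1ccco1)Cc1cc(Br)ccc1O`: compound 3 gives 40500 nM.

Compound 2 stands second highest of the three numbers; its nearest neighbour is compound 3 and its furthest is compound 1, and both gaps lie within the scatter, so the three cannot be ranked. Compound 4, `CCOC(=O)N1CCC(N(Cc2cc(Br)ccc2O)C(=O)N(C)C)CC1`, differs from compound 2 by bromo in place of chloro on an aromatic carbon. Going by the values given here, no pair of measured compounds isolates this change; compound 3 already carries the 5-bromo-2-hydroxyphenyl group with a different remainder of the molecule and sits alongside compound 2. On that basis the step of a 1.0-fold higher number from compound 2 to compound 4 (0.02 log units; within the scatter) is expected to stay within the scatter. Compound 4 is therefore estimated at 40000 nM, between 20000 nM and 80000 nM, in this assay.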

Compound 4, half-maximal inhibitory concentration: 41800 nM
Estimate against measurement, compound 4: 1.0-fold (0.02 log units) below; low and high end bracket the measured number.
By their numbers in this assay, from the lowest: compounds 1, 2, 3 and 4 (each within the scatter of the next).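

Going by these compounds alone, the exchange of chloro for bromo, para to the hydroxy group, is the first change at this position that can be read on its own, and in this assay it gives a 1.1-fold higher number from compound 2 to compound 4 (0.04 log units; within the scatter) and so no separation between the two halogens. On this read-out, the 5-chloro-2-hydroxyphenyl and 5-bromo-2-hydroxyphenyl groups cannot be told apart in this molecule. Nothing available offers an explanation for this result. The compounds shown leave open whether an amine or a methoxy group at this position would give a step beyond the scatter. They also leave open whether the same exchange would read alike with the furan-2-ylmethyl remainder of compound 3.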